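The compounds below may be only part of what the source reports. "The series", "measured", "known", "first", "only" and "open" are said of these compounds alone.

Compound 1 `CC1=C(C(=O)Nc2ccc(Br)cc2)C(c2ccc(Cl)cc2Cl)N=C(SCc2cccc(Cl)c2)N1` and compound 2 `CC1=C(C(=O)Nc2ccc(Br)cc2)C(c2ccc(Cl)cc2Cl)N=C(SCc2ccc(Cl)cc2)N1` share one core and differ only in that (4-chlorophenyl in place of 3-chlorophenyl on a saturated chain carbon bound to a sulfur). In a functional assay on the whole organism (artery, strain albino) with Rattus norvegicus as the target, with a stated time of 30 min, at a dose of 10 mg/kg by the oral route (on this read-out lower numbers stand for less inhibition and higher numbers for more inhibition at the one dose given (going by the name of the read-out)), compound 1 gives 3.1%, and compound 2 gives 6.7%; the change produced a number 3.6 percentage points higher from compound 1 to compound 2 (within the scatter). Compound 3 `CC1=C(C(=O)Nc2ccc([N+](=O)[O-])cc2)C(c2ccc(Br)cc2)N=C(SCc2cccc(Cl)c2)N1` rests on a different core; the difference between the cores of compound 3 and compound 1 is not broken down here. In this assay compound 3 gives 2.6%, close to both compound 1 and compound 2. Compound 4 `CC1=C(C(=O)Nc2ccc([N+](=O)[O-])cc2)C(c2ccc(Br)cc2)N=C(SCc2ccc(Cl)cc2)N1` is not yet measured; it differs from compound 3 in that (4-chlorophenyl in place of 3-chlorophenyl on a saturated chain carbon bound to a sulfur), the same change at the same place as from compound 1 to compound 2. From compound 3 to compound 4 a step of a number 3.4 percentage points higher from compound 3 to compound 4 (within the scatter) is expected, resting on the earlier a number 3.6 percentage points higher from compound 1 to compound 2 (within the scatter). Compound 4 is accordingly estimated at 6%, within a range from -3% to 15%.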

Compound 4, a percentage reported as inhibition, in the whole organism at one dose (the size of the read-out at that dose, not a potency): 6.2%
Compound 4: middle estimate off by 0.2 percentage points, on the low side; the measured number falls inside the stated range.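

In this assay, 4-chlorophenyl in place of 3-chlorophenyl on a saturated chain carbon bound to a sulfur gives a number 3.6 percentage points higher from compound 3 to compound 4 (within the scatter), and the step reads alike on the two cores: the same change on two cores in this assay, a number 3.6 percentage points higher (within the scatter) from compound 1 to compound 2 and a number 3.6 percentage points higher (within the scatter) from compound 3 to compound 4, 0 percentage points apart, within the scatter of two such steps

Among these compounds, both steps lie within the scatter, so this agreement shows only that the change gives no step beyond the scatter on either core; it does not establish a real effect of the change. Two cores are also too few to show that the step would carry over to any other core in the series.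

The compounds shown leave open how an unsubstituted phenyl, a pyridine ring or a carboxylic acid on the benzyl ring would read at this place. From the compounds shown here alone, it also remains open whether a longer chain between the sulfur and the ring would give a step beyond the scatter.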